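Removing one chlorine from the 3,4-dichlorobenzyl group

The source may report more compounds than this note shows. Statements on the series, on what has been measured and on what is new or still open speak of the compounds shown alone.

In a functional assay on K562 cells (Homo sapiens) for antiproliferative activity, read by MTT assay, with a stated time of 48 h (a higher number here means a weaker inhibitor, a lower number a stronger inhibitor), compound 1 `COc1ccc(-c2ccc3c(c2)C(=O)C(=O)N3)cc1`, with hydrogen on the amide-type nitrogen, gives 6920 nM. Compound 2 `COc1ccc(-c2ccc3c(c2)C(=O)C(=O)N3Cc2ccc(F)cc2)cc1` gives 560 nM, and compound 3 `COc1ccc(-c2ccc3c(c2)C(=O)C(=O)N3Cc2ccc(Cl)c(Cl)c2)cc1` gives 430 nM, which lies within the scatter of compound 2 and well under compound 1. Compound 4 `COc1ccc(-c2ccc3c(c2)C(=O)C(=O)N3Cc2cccc(Cl)c2)cc1` differs from compound 3 by hydrogen in place of chloro on an aromatic carbon, so 3,4-dichlorobenzyl becomes 3-chlorobenzyl. Adding the benzyl groups gave the large steps of a 12-fold lower number from compound 1 to compound 2 (1.09 log units; beyond the scatter) and a 16-fold lower number from compound 1 to compound 3 (1.21 log units; beyond the scatter), but compound 4 keeps a benzyl group. The closer precedent is the change between benzyl groups, a 1.3-fold lower number from compound 2 to compound 3 (0.11 log units; within the scatter), which stayed within the scatter. The expected result is a 1.2-fold higher number from compound 3 to compound 4 (0.08 log units; within the scatter), with no shift beyond the scatter. Compound 4 is estimated at 520 nM, within an expected range of 250 nM to 1100 nM.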

Compound 4, half-maximal inhibitory concentration: 200 nM
Estimate against measurement, compound 4: 2.6-fold (0.41 log units) above, outside the stated range (below it).
By their numbers in this assay, from the lowest: compound 4; then compounds 3 and 2 (each within the scatter of the next); then compound 1.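

In this assay this chloro group proves dispensable: going from 3,4-dichlorobenzyl to 3-chlorobenzyl gives a 2.2-fold lower number from compound 3 to compound 4 (0.33 log units; beyond the scatter), so a change on the benzyl group now moves the number beyond the scatter. Compound 4 also separates from the 4-fluorobenzyl compound, with a 2.8-fold lower number from compound 2 to compound 4 (0.45 log units; beyond the scatter), and the step from the nitrogen bearing hydrogen grows to a 35-fold lower number from compound 1 to compound 4 (1.54 log units; beyond the scatter). Nothing available explains why losing this chloro group lowers the number. The compounds shown leave open whether the remaining chloro group matters, since plain benzyl is not among them, and whether an amine or a carboxylic acid in its place would keep the number this low.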